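Ethoxy Added to the Phenyl of Compound 1

A few compounds are considered here, and "the series" means these few. Any claim that something is new, unique, unknown or untested is made for them only; others in the source may bear on it.

In a functional assay on HepG2 cells (Homo sapiens) for antiproliferative activity, read by MTT assay, with a stated time of 48 h (on this read-out lower numbers stand for stronger inhibition of growth and higher numbers for weaker inhibition of growth), compound 1 `COC(=O)N1N=C(c2ccccc2)CC1c1cc(OC)c(OC)c(OC)c1` gives 3950 nM. Compound 2 `CCOC(=O)N1N=C(c2ccccc2)CC1c1cc(OC)c(OC)c(OC)c1` gives 5950 nM, and compound 3 `COC(=O)N1N=C(c2ccccc2)CC1c1ccc(OC)c(OC)c1` gives 9150 nM. Compound 1 thus stands level with compound 2 at the low end of these three numbers, and clear of compound 3. Compound 4 `CCOc1cccc(C2=NN(C(=O)OC)C(c3cc(OC)c(OC)c(OC)c3)C2)c1` differs from compound 1 in one place, with phenyl becoming 3-ethoxyphenyl: ethoxy in place of hydrogen on an aromatic carbon. Among the compounds with values here, two measured steps bear on this only indirectly, as neither involves that aromatic carbon. Methyl in place of hydrogen on a saturated chain carbon gave a 1.5-fold higher number from compound 1 to compound 2 (0.18 log units; within the scatter). Hydrogen in place of methoxy on an aromatic carbon elsewhere in the molecule gave a 2.3-fold higher number from compound 1 to compound 3 (0.36 log units; beyond the scatter). That second step is the closer comparison, but it removes a group instead of adding one, so it suggests a size and no firm direction. In this assay no step beyond the scatter is expected, and the estimated step is a 1.3-fold higher number from compound 1 to compound 4 (0.10 log units; within the scatter). For compound 4 the expected value is 5000 nM, with an estimated range from 2000 nM to 12000 nM.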

Compound 4, concentration for 50% growth inhibition: 8360 nM
Estimate against measurement, compound 4: 1.7-fold (0.22 log units) below; measured number inside the range.
By their numbers in this assay, from the lowest: compounds 1, 2, 4 and 3 (each within the scatter of the next, the first and the last beyond it).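

Ethoxy in place of hydrogen on this aromatic carbon, meta to a large group, gives a 2.1-fold higher number from compound 1 to compound 4 (0.33 log units; beyond the scatter) in this assay. This is the first change shown on the phenyl of compound 1, and it shows that a substituent here can move the number beyond the scatter, modestly and toward weaker inhibition of growth. Nothing measured here accounts for this step.

As far as these compounds go, it remains open whether a hydroxyl group, an amine or a longer chain such as propoxy on the same aromatic carbon would give a number closer to that of compound 1 or further from it. Also open, from the compounds shown here alone, is whether ethoxy on a different carbon of this phenyl ring would produce a step of similar size.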